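Naphthyl attachment point and cell tolerance: outlook for compound 4

This account rests on a few compounds, and the source may have more. Where it says the series, first, only, none or still open, it means among the compounds named here.

Measured so far in a toxicity assay on MDCK cells (Canis lupus familiaris) for cytotoxicity, read by crystal violet staining, with a stated time of 48 h; a higher number here means that more compound is tolerated, a lower number that less compound is tolerated:
- compound 1 `Cc1ccc2[nH]c(=O)c(CN(Cc3ccccc3)Cc3ccc(C(C)(C)C)cc3)cc2c1`: this assay reports only a limit, > 5000 nM.
- compound 2 `CCc1ccc2[nH]c(=O)c(CN(Cc3ccc(F)cc3)Cc3ccc4ccccc4c3)cc2c1`: this assay reports only a limit, > 5000 nM.
- compound 3 `CCc1ccc2[nH]c(=O)c(CN(Cc3cccc(F)c3)Cc3ccc4ccccc4c3)cc2c1`: this assay reports only a limit, > 5000 nM.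

Compound 2 therefore stands at the limit of > 5000 nM in this assay, at which 3 of the 3 values shown sit; no number is known for it. Going by the values given here, the one comparable step, a step that the two limits leave unreadable from compound 2 to compound 3, cannot be read because both ends are limits, so no measured step in this assay bears on the change now considered.

Compound 4 `CCc1ccc2[nH]c(=O)c(CN(Cc3ccc(F)cc3)Cc3cccc4ccccc34)cc2c1` differs from compound 2 by naphthalen-1-yl in place of naphthalen-2-yl on a saturated chain carbon bound to an amine nitrogen. With every value shown sitting at the limit, no direction is expected for compound 4 beyond the scatter; the step that the limit leaves unreadable from compound 2 to compound 4 is an expectation only. Compound 4 is estimated at 8000 nM, with a range of 4000 nM to 30000 nM, most likely reported again as a limit.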

Compound 4, half-maximal cytotoxic concentration: > 5000 nM
Compound 4: no number, only a limit (the forecaster's own chance of this, stated with the estimate: 85%); the middle value lies beyond the limit too.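

No step can be read from compound 2 to compound 4, since both ends are limits: the limit of > 5000 nM in this assay, at which 4 of the 4 values shown sit. The compounds shown leave open where any half-maximal cytotoxic concentration lies, and whether naphthalen-1-yl in place of naphthalen-2-yl alters it.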